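Pyrimidin-2-yl for 5-methylpyrazin-2-yl on the amide carbonyl

The source may hold more compounds than are shown below. What is called first, only, known or untested is meant among the compounds shown, and "the series" means these compounds.

The series is read in a functional assay on MIA PaCa-2 cells (Homo sapiens) for inhibition, read by MTT assay, with a stated time of 72 h; on this read-out higher numbers stand for weaker inhibition and lower numbers for stronger inhibition. Compound 1 `Cc1cnc(C(=O)Nc2cc(F)cc3cccnc23)cn1` carries a 5-methylpyrazin-2-yl group on the carbonyl carbon and gives 310 nM. Compound 2 `O=C(Nc1cc(F)cc2cccnc12)c1ncccn1` differs from it only in that ring: pyrimidin-2-yl in place of 5-methylpyrazin-2-yl on a carbonyl carbon. In this assay compound 2 gives 300 nM. The step of a 1.0-fold lower number from compound 1 to compound 2 (0.01 log units; within the scatter) is within the scatter, so the two values are read as the same.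

Compound 3 `Cc1cnc(C(=O)Nc2cc(OCCC3CCN(C(=O)OC(C)(C)C)CC3)cc3cccnc23)cn1` keeps the 5-methylpyrazin-2-yl carbonyl of compound 1 but carries a larger core; the difference between the two cores is not broken down here. In this assay compound 3 gives 9000 nM, which stands well above the numbers of compound 1 and compound 2, with both gaps beyond the scatter. Compound 3 is therefore the weakest inhibitor measured so far.

Compound 4 `CC(C)(C)OC(=O)N1CCC(CCOc2cc(NC(=O)c3ncccn3)c3ncccc3c2)CC1` is not yet measured. It stands to compound 3 as compound 2 stands to compound 1: pyrimidin-2-yl in place of 5-methylpyrazin-2-yl on a carbonyl carbon. The place is described in the same words for both pairs, so this is the same change made on the core of compound 3. The expected step from compound 3 to compound 4 is no change at the digits printed from compound 3 to compound 4 (within the scatter), resting on the fact that the same change gave only a 1.0-fold lower number from compound 1 to compound 2 (0.01 log units; within the scatter) in this assay. Compound 4 is thus estimated at 9000 nM, with a likely range from 4000 nM to 20000 nM.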

Compound 4, half-maximal inhibitory concentration: > 10000 nM
Compound 4 ended at the assay's limit; the forecaster's own chance of this, stated with the estimate: 10%; middle value at least 1.1-fold (0.04 log units) from the limit.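

Carried to the larger core in this assay, pyrimidin-2-yl in place of 5-methylpyrazin-2-yl on the amide carbonyl gives an at least 1.1-fold higher number from compound 3 to compound 4 (0.04 log units; that floor lies within the scatter), and this step is only a floor. Compound 4 reads > 10000 nM, which is a limit of the assay and not a number, so the pair fits no change on this core and equally fits a loss of unknown size; it does not show that the change is neutral here, and it gives no sign that it behaves differently here either. Set beside the step on the smaller core, the reading for transfer between the two cores stays undecided: the same change on two cores in this assay, a 1.0-fold lower number (0.01 log units; within the scatter) from compound 1 to compound 2 and an at least 1.1-fold higher number (0.04 log units; that floor lies within the scatter) from compound 3 to compound 4; the limit leaves it open whether they differ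

The compounds shown leave open which part of the larger core separates compound 3 from compound 1, as those two differ by more than one place and the difference between their cores is not broken down. They also leave open whether the change between the two rings would read the same on a core with an amine or a carboxylic acid at the end of the longer chain, where the size of the step might be measured and not just bounded.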